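Replacing a morpholine with a carbamate on the propyl chain

This account rests on a few compounds, and the source may have more. Where it says the series, first, only, none or still open, it means among the compounds named here.

Of the compounds shown here, two have been measured in a physicochemical assay for solubility, in phosphate buffer, with a stated time of 18 h, at pH 7.4; a lower number here means a less soluble compound, a higher number a more soluble compound. Compound 1 `Nc1nc(-c2ccc(Cl)cc2)nn1-c1ncnc2cc(Cl)ccc12` gives 5000 nM in this assay. Compound 2 `COc1cc2ncnc(-n3nc(-c4ccccn4)nc3N)c2cc1OCCCN1CC(C)OC(C)C1` gives 8000 nM in this assay, the highest of the two numbers, although its gap to compound 1 lies within the usual scatter, so the two cannot be ranked against each other.

Compound 3 `COc1cc2ncnc(-n3nc(-c4ccccn4)nc3N)c2cc1OCCCNC(=O)OCC(F)(F)F` has not been measured. It differs from compound 2 in one place: ((2,2,2-trifluoroethoxy)carbonyl)amino in place of 2,6-dimethylmorpholin-4-yl on a saturated chain carbon, three bonds along the chain from an oxygen on an aromatic ring. The 2,6-dimethylmorpholin-4-yl ring leaves and a chain group carrying one hydrogen-bond donor enters.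

For the measured compounds named here, no measured pair shows what this kind of change does here, so the expectation rests on the two values alone and on the size of the change. A drop in solubility beyond the scatter is expected, with a step from compound 2 to compound 3 estimated at a 5.3-fold lower number from compound 2 to compound 3 (0.73 log units; beyond the scatter). Compound 3 is therefore estimated at 1500 nM in this assay, within a range from 400 nM to 6000 nM.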

Compound 3, solubility: 100 nM
The estimate for compound 3 lay 15-fold (1.18 log units) above the measured number; measured number outside the range, below it.
By their numbers in this assay, from the lowest: compound 3; then compounds 1 and 2 (each within the scatter of the next).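

In this assay, this replacement gives an 80-fold lower number from compound 2 to compound 3 (1.90 log units; beyond the scatter), the first step measured at this place, on a saturated chain carbon, three bonds along the chain from an oxygen on an aromatic ring. The rest of the molecule stays the same, so what sits at the end of the propyl chain can clearly matter for this read-out, something the two earlier values could not show because they lie within the scatter of each other. Nothing measured here explains why the number falls so far.

The compounds shown leave open whether the step goes with the departure of the 2,6-dimethylmorpholin-4-yl ring or with the arrival of the ((2,2,2-trifluoroethoxy)carbonyl)amino group. A dimethylamino group or an ethoxycarbonylamino group, which has no fluorine, on the same propyl chain would help separate the two.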